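From a Carbamoyl Side Chain to a Smaller Group

A few compounds are considered here, and "the series" means these few. Any claim that something is new, unique, unknown or untested is made for them only; others in the source may bear on it.

In a physicochemical assay for solubility, at pH 6.5 (on this read-out lower numbers stand for lower solubility and higher numbers for higher solubility), compound 2 (`CS(=O)(=O)c1ccc(-c2cnc3ccc(-c4cccc(C(=O)NCCO)c4)nn23)cc1`) reads > 100000 nM as a limit and not a number. Compound 1 (`C[S+]([O-])c1cccc(-c2ccc3ncc(-c4ccc(C(N)=O)cc4)n3n2)c1`) reads < 5000 nM in this assay and this too is a limit. Among the compounds with values here, neither compound therefore offers an exact number, and no measured step links them to the next compound.

Compound 3 (`C[S+]([O-])c1cccc(-c2ccc3ncc(-c4ccc(S(C)(=O)=O)cc4)n3n2)c1`) departs from compound 2 on an aromatic carbon of a six-membered aromatic ring of carbon only, meta to a large group. There the (2-hydroxyethyl)carbamoyl leaves and a group with no common name enters (a group of 3 heavy atoms (1 carbon, 1 oxygen, 1 sulfur; no ring) in place of a group of 6 heavy atoms (3 carbon, 1 nitrogen, 2 oxygen; no ring), on an aromatic carbon). With that side chain gone, compound 3 is expected to read closer to compound 1, whose < 5000 nM stands as a limit. The expected change an at least 25-fold lower number from compound 2 to compound 3 (1.39 log units; beyond the scatter) in this assay is a large fall, well beyond the usual scatter. For compound 3 the estimate is 4000 nM with an expected range of 1000 nM to 30000 nM and a real chance that the measurement returns only a limit.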

Compound 3, solubility: 157000 nM
Compound 3: middle estimate off by 39-fold (1.59 log units), on the low side; measured number outside the range, above it.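

Within the data shown here, compound 3 gives the first exact number in this assay, and it shows that a high reading does not depend on the (2-hydroxyethyl)carbamoyl at this aromatic carbon: that group has gone in compound 3, and the reading remains high. With methylsulfonyl in place of carbamoyl on an aromatic carbon, the read-out shows an at least 31-fold higher number from compound 1 to compound 3 (1.49 log units; beyond the scatter), so this single change separates two very different readings on the same core. Compound 2 reads only as a limit, so the step from it to compound 3 cannot be read in size or in direction: the limit of > 100000 nM in this assay, at which 1 of the 3 values shown sits.

Going by these compounds, it remains open how an amine or a carboxylic acid would read in place of the methylsulfonyl on that aromatic carbon, and so whether the large step belongs to methylsulfonyl in particular or would be shared by other groups there. Also open, on these data alone, is how a longer chain would read in place of the small group with no common name, and where compound 2 truly stands against compound 3 in this assay.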